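The compounds below may be only part of what the source reports. "The series", "measured", "known", "first", "only" and "open" are said of these compounds alone.

Working notes on the series. Of the compounds shown here, three sharing one core have been measured in a physicochemical assay for lipophilicity, at pH 7.4; a lower number here means a more polar compound, a higher number a more lipophilic compound. Compound 1 `CCS(=O)(=O)c1ccc(CNS(=O)(=O)c2ccc3c(c2)C(=O)CC(C2CCOCC2)O3)nc1` gives 0.32 in this assay. Compound 2 `CCc1ccc(N(CC(C)C)S(=O)(=O)c2ccc3c(c2)C(=O)C[C@H](C2CCOCC2)O3)cc1` gives 4.24 in this assay. Compound 3 `CC(C)CN(c1ccc(F)cc1)S(=O)(=O)c1ccc2c(c1)C(=O)CC(C1CCOCC1)O2` gives 3.48 in this assay. Among these three numbers compound 2 stands highest: the nearest number is that of compound 3, which lies lower by a gap beyond the usual scatter, and the furthest is that of compound 1, which lies lower by a gap far beyond the usual scatter. For the measured compounds named here, no pair of these measured compounds differs in a single place, so no isolated step between measured compounds is available.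

The next compound, compound 4 `CCc1ccc(N(CC(C)C)S(=O)(=O)c2ccc3c(c2)C(=O)C[C@@H](C2CCOCC2)O3)cc1`, has not yet been measured in this assay. Its relation to compound 2 is as follows: the two compounds have the same atoms and bonds and differ only in configuration as drawn: 1 of 1 stereo elements differ; a stereocentre at a saturated ring carbon is drawn R in compound 2 and S in compound 4. Nothing leaves and nothing enters. Given that the two compounds have the same atoms and bonds and differ only in configuration as drawn: 1 of 1 stereo elements differ; a stereocentre at a saturated ring carbon is drawn R in compound 2 and S in compound 4 describes the whole of the difference, the step of no change at the digits printed from compound 2 to compound 4 (within the scatter) is expected to be none beyond the usual scatter of this assay, in neither direction. Compound 4 is therefore estimated at 4.24 in this assay, with a range from 3.94 to 4.54, the value of compound 2 serving as the anchor.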

Compound 4, distribution coefficient: 4.2
Estimate against measurement, compound 4: 0.04 log units above; low and high end bracket the measured number.
By their numbers in this assay, from the lowest: compound 1; then compound 3; then compounds 4 and 2 (each within the scatter of the next).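

In this assay the series now has its first isolated step, a number 0.04 log units lower from compound 2 to compound 4 (within the scatter), and it can be assigned to the stereocentre at the saturated ring carbon alone: the fact that compounds 2 and 4 differ only in the configuration as drawn. With the substituents carried by this pair, drawing that carbon as R or as S therefore makes no difference beyond the usual scatter in this read-out. The earlier compounds shown here could not show this, since no two of them differed in a single place and compounds 1 and 3 are drawn without any configuration at that carbon.

Left open is whether the two configurations would remain equally indistinguishable in this assay if another group stood elsewhere on the molecule, for example an amine or a carboxylic acid in place of the ethyl group. The pair also says nothing about whether the same stereocentre matters in any read-out other than this one, so the present result should be taken to apply to this distribution coefficient and to this pair only.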